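Shortening a Chain in a Compound Held at a Limit

The source may hold more compounds than are shown below. What is called first, only, known or untested is meant among the compounds shown, and "the series" means these compounds.

- Compound 1 `CCCCC(C(=O)COc1c(F)c(F)cc(F)c1F)n1cc([C@@](C)(NCc2ccc3ncccc3c2)C(C)C)nn1`: > 10000 nM, a limit
- Compound 2 `CCCCC(C(=O)COc1c(F)c(F)cc(F)c1F)n1cc([C@](C)(CC(C)C)NCc2ccc3ncccc3c2)nn1`: > 10000 nM, a limit
- Compound 3 `CCC(C(=O)COc1c(F)c(F)cc(F)c1F)n1cc([C@](C)(CC(C)C)NCc2ccc3ncccc3c2)nn1`: not yet measured

In an ADME assay on BEMS cells (Bos taurus) for cytotoxicity (a higher number here means a weaker inhibitor, a lower number a stronger inhibitor), compound 2 gives > 10000 nM, which is a limit and not a number. The two measured compounds share one reading: the limit of > 10000 nM in this assay, at which 2 of the 2 values shown sit. Compound 3 carries hydrogen in place of ethyl on a saturated chain carbon, three bonds along the chain from an aromatic nitrogen and a carbonyl carbon. For the measured compounds named here, the only measured step is a step that the two limits leave unreadable from compound 1 to compound 2, and it lies at a different place, so it offers no size to carry over. No clear shift in either direction is therefore expected in this assay. The estimated change is a step that the limit leaves unreadable from compound 2 to compound 3. For compound 3 the expected value is 12000 nM, with an estimated range from 5000 nM to 30000 nM.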

Compound 3, half-maximal inhibitory concentration: > 10000 nM
Compound 3: a limit, no number; the forecaster's own chance of this, stated with the estimate: 85%; the middle value lies beyond the limit too.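

In this assay, for the compounds shown here, compound 3 gives > 10000 nM, which is a limit, so no step from compound 2 can be read. The compounds shown leave open what number any of the three would give, and so whether hydrogen in place of ethyl changes the reading at all.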